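Shrinking the Hydroxylated Carbocycle in a Kinase Inhibitor Series

The source may report more compounds than this note shows. Statements on the series, on what has been measured and on what is new or still open speak of the compounds shown alone.

Of the compounds shown here, two have been measured in an assay on isolated protein for inhibition of protein kinase C delta type (Homo sapiens), read by TR-FRET, with a stated time of 2 h; on this read-out higher numbers stand for weaker inhibition and lower numbers for stronger inhibition. Compound 1 `N#Cc1cnc(NCc2cncnc2C(F)(F)F)cc1N[C@H]1CC[C@@H](O)CC1` gives 450 nM. Compound 2 `CC1(C)C[C@H](Nc2nc(NCc3cnccc3C(F)(F)F)ncc2C#N)CC[C@@H]1O` gives 800 nM, the higher of the two numbers, though its gap to compound 1 lies within the usual scatter, so the two cannot be ordered. Compound 3 `CC1(C)[C@@H](Nc2nc(NCc3cnccc3C(F)(F)F)ncc2C#N)C[C@@H]1O` has not been measured. It differs from compound 2 in one place: 3-hydroxy-2,2-dimethylcyclobutyl in place of 4-hydroxy-3,3-dimethylcyclohexyl on a nitrogen on an aromatic ring. For the measured compounds named here, no measured pair tracks this change, so its size is unknown; swapping a six-membered non-aromatic ring for a four-membered one is a substantial rearrangement, and a modest weakening seems the likeliest outcome. The step of a 1.9-fold higher number from compound 2 to compound 3 (0.27 log units; within the scatter) is therefore expected to run towards weaker inhibition. Compound 3 is estimated at 1500 nM, with a plausible range from 400 nM to 6000 nM.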

Compound 3, half-maximal inhibitory concentration: 2000 nM
Compound 3: middle estimate off by 1.3-fold (0.12 log units), on the low side; the measured number falls inside the stated range.
By their numbers in this assay, from the lowest: compounds 1 and 2 (each within the scatter of the next); then compound 3.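

The pair gives this series its first reading of a change at a single place: on the nitrogen on the aromatic ring, 3-hydroxy-2,2-dimethylcyclobutyl in place of 4-hydroxy-3,3-dimethylcyclohexyl gives a 2.5-fold higher number from compound 2 to compound 3 (0.40 log units; beyond the scatter) in this assay. So this position responds to the carbocycle it carries, and the four-membered ring is the weaker of the two here, though the size of the step is modest and it rests on one pair. Nothing at hand explains the step.

This single pair changes ring size and the placement of the hydroxy and dimethyl groups together, so it cannot separate their contributions. Going by these compounds, how a five-membered 3-hydroxycyclopentyl ring, or an amine or a carboxylic acid in place of the hydroxy group, would read at this position remains open.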